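Sulfur substituent changes on a shared core: compound 4

The source may report more compounds than this note shows. Statements on the series, on what has been measured and on what is new or still open speak of the compounds shown alone.

Measured so far in a functional assay on HepG2 cells (Homo sapiens) for inhibition, read by MTT assay, with a stated time of 72 h; on this read-out lower numbers stand for stronger inhibition and higher numbers for weaker inhibition:
compound 1 `C#CCSc1nc(Nc2cccc(OC)c2)c2ccncc2n1` — 920 nM
compound 2 `CCSc1nc(Nc2cccc(OC)c2)c2ccncc2n1` — 10700 nM
compound 3 `C/C=C/Sc1nc(Nc2cccc(OC)c2)c2ccncc2n1` — 18100 nM

Compound 3 gives the highest number of the three; the step of a 1.7-fold higher number from compound 2 to compound 3 (0.23 log units; within the scatter) lies within the scatter, while the step of a 20-fold higher number from compound 1 to compound 3 (1.29 log units; beyond the scatter) is large. Compound 4 `COc1cccc(Nc2nc(SCC3CC3)nc3cnccc23)c1` differs from compound 3 by cyclopropylmethyl in place of prop-1-en-1-yl on a sulfur.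

The step of a 12-fold higher number from compound 1 to compound 2 (1.07 log units; beyond the scatter) shows that losing the alkyne costs much. The step from compound 2 to compound 3 shows an ethyl and a propenyl on the sulfur behaving alike. A cyclopropylmethyl resembles those more than a propargyl, so no step beyond the scatter is expected for compound 4. Compound 4 is estimated at 12000 nM (range 4000 nM to 36000 nM), a step of a 1.5-fold lower number from compound 3 to compound 4 (0.18 log units; within the scatter).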

Compound 4, half-maximal inhibitory concentration: 24900 nM
Estimate against measurement, compound 4: 2.1-fold (0.32 log units) below; measured number inside the range.
By their numbers in this assay, from the lowest: compound 1; then compounds 2, 3 and 4 (each within the scatter of the next, the first and the last beyond it).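

In this assay, a cyclopropylmethyl group on the sulfur behaves like prop-1-en-1-yl (a 1.4-fold higher number from compound 3 to compound 4 (0.14 log units; within the scatter)), so adding a three-membered ring recovers nothing. Against the ethyl group there is only a modest shift (a 2.3-fold higher number from compound 2 to compound 4 (0.37 log units; beyond the scatter)), whereas the gap to the propargyl group remains large (a 27-fold higher number from compound 1 to compound 4 (1.43 log units; beyond the scatter)), leaving compound 1 apart from the other three compounds. No evidence is available to explain these differences.

From the compounds shown here alone, whether the terminal alkyne itself is required remains open; a but-2-yn-1-yl or cyanomethyl group on the sulfur would address this.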